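This account rests on a few compounds, and the source may have more. Where it says the series, first, only, none or still open, it means among the compounds named here.

The series shares one core, shown by compound 1 `O=C(O)Cc1sc(C(c2ccc(F)cc2)c2ccc(F)cc2)nc1-c1ccc(Cl)cc1`, which in an in vitro functional assay on HEK285-7 cells for antagonist activity at prostaglandin D2 receptor 2 (Homo sapiens), read by BRET and beta-arrestin recruitment (on this read-out higher numbers stand for larger maximal responses and lower numbers for smaller maximal responses), reaches 80%. Compound 2 `NS(=O)(=O)c1cccc(-c2nc(C(c3ccc(F)cc3)c3ccc(F)cc3)sc2CC(=O)O)c1` differs from it at one aromatic carbon, and in this assay compound 2 reaches 55%. Within the data shown here, the step of a number 25 percentage points lower from compound 1 to compound 2 (beyond the scatter) is the only measured change at that position. Among the two numbers so far, compound 2 stands lowest, with compound 1 as its nearest neighbour at a higher value, beyond the scatter.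

Compound 3 `Cc1cc(-c2nc(C(c3ccc(F)cc3)c3ccc(F)cc3)sc2CC(=O)O)ccn1` has not yet been measured. It differs from compound 2 as follows: 2-methylpyridin-4-yl in place of 3-sulfamoylphenyl on an aromatic carbon. Among the measured compounds shown here, the one measured step that bears on this position, from compound 1 to compound 2, was modest and downward; no measured step involves the 2-methylpyridin-4-yl group itself. Since the group that leaves is the one whose entry coincided with the drop, a partial return toward the value of compound 1 is expected, though with wide uncertainty. Compound 3 is therefore estimated at 65%, within 45% to 85%, which would mean a step of a number 10 percentage points higher from compound 2 to compound 3 (within the scatter).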

Compound 3, largest response reached (reported as efficacy), in percent of the reference or control that the assay uses: 80%
Compound 3: the middle estimate sits 15 percentage points below what was measured; low and high end bracket the measured number.
By their numbers in this assay, from the lowest: compound 2; then compounds 1 and 3 (each within the scatter of the next).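

At the aromatic carbon next to the ring nitrogen, 2-methylpyridin-4-yl in place of 3-sulfamoylphenyl in this assay gives a number 25 percentage points higher from compound 2 to compound 3 (beyond the scatter) and so shows that the lower number of compound 2 does not extend to every group that replaces 4-chlorophenyl. Among these compounds, the other comparison shows no change at the digits printed from compound 1 to compound 3 (within the scatter) and thus that a six-membered aromatic ring with 1 hetero atom can stand here in place of one of carbon only with no difference this read-out can separate, which leaves compound 2 as the one compound of the three set apart from both others. Nothing among the data shown gives a reason for either step.

The compounds shown leave open whether the methyl group of compound 3 has any part in its number, which pyridin-4-yl without that methyl would address, and whether the lower number of compound 2 belongs to the sulfamoyl group itself or to its place on the phenyl ring, which 4-sulfamoylphenyl and 3-methanesulfonylphenyl would address. They also leave open how far these results hold when the carboxymethyl group gives way to a longer chain such as carboxyethyl.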